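The compounds below may be only part of what the source reports. "The series", "measured", "known", "first", "only" and "open" are said of these compounds alone.

In a functional assay on MCF7 cells (Homo sapiens) for antiproliferative activity, read by sulforhodamine B assay, with a stated time of 48 h (a higher number here means a weaker inhibitor, a lower number a stronger inhibitor), compound 1 (`COc1ccc(CNC(=O)c2ccccc2-c2ccc(F)cc2)cc1`) gives > 50000 nM as its reading, which is a limit of the assay and not a number. Compound 2 (`COc1ccc(CNC(=O)c2ccccc2-c2ccc(F)cc2)cc1OC`) shows > 50000 nM in this assay as its reading, and this too is only a limit. Where compound 2 stands is therefore known only as the limit of > 50000 nM in this assay, at which 2 of the 2 values shown sit, and no true value is available for it.

Compound 3 (`COc1cc(CNC(=O)c2ccccc2-c2ccc(F)cc2)cc(OC)c1OC`) differs from compound 2 by a further methoxy in place of hydrogen on an aromatic carbon is the whole change.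

Among the measured compounds shown here, the only measured step of this kind is a step that the two limits leave unreadable from compound 1 to compound 2 and it offers no size to carry forward. With that single unreadable step as the guide, no step beyond the scatter is expected in this assay and no direction can be favoured. The reading for compound 3 may well be a limit again.

The expected change is a number no higher from compound 2 to compound 3 (the limit leaves the size open) on this estimate. Compound 3 is estimated at 50000 nM in this assay, with an expected range from 20000 nM to 100000 nM for its reading.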

Compound 3, half-maximal inhibitory concentration: > 50000 nM
Compound 3: no number, only a limit (the forecaster's own chance of this, stated with the estimate: 75%); the middle value lies on the limit itself.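

Compound 2 and compound 3 both give only a limit in this assay, not a number, so the step between them cannot be read and no size can be carried forward. The compounds shown leave open what true reading any of them has and how much each added methoxy changes it, since all that is known is this: the limit of > 50000 nM in this assay, at which 3 of the 3 values shown sit.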